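A few compounds are considered here, and "the series" means these few. Any claim that something is new, unique, unknown or untested is made for them only; others in the source may bear on it.

Measured in an assay on tissue (HeLa cells) for inhibition of Indoleamine 2,3-dioxygenase 1 (Homo sapiens), read by spectrophotometry; a lower number here means a stronger inhibitor, a higher number a weaker inhibitor:
Compound 1 `O/N=C(/Nc1cccc(C(F)(F)F)c1)c1ccc2occc2c1` gives 1900 nM.
Compound 2 `O/N=C(/Nc1ccc(F)c(C(F)(F)F)c1)c1ccc2occc2c1` gives 2200 nM.
Compound 3 `O/N=C(/Nc1ccc(Cl)c(F)c1)c1ccc2occc2c1` gives 10300 nM.

Compound 1 has the lowest number of the three; compound 2 is nearest to it, and the step of a 1.2-fold higher number from compound 1 to compound 2 (0.06 log units; within the scatter) is within the scatter, so the two cannot be told apart. Compound 3 stands furthest away, with a clearly higher number than compound 1.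

Compound 4 `O/N=C(/Nc1cccc(Oc2ccccc2)c1)c1ccc2occc2c1` differs from compound 1 in one place: phenoxy in place of trifluoromethyl on an aromatic carbon. Among the compounds with values here, none of the measured steps changes the trifluoromethyl group itself; the only single-place step, from compound 1 to compound 2, adds a fluoro and stays within the scatter. Compound 3, which carries fluoro and chloro instead of the trifluoromethyl, shows that altering this part of the ring can push the number well up, but that is a different change. The expectation for compound 4 is therefore uncertain, with a step of a 1.6-fold higher number from compound 1 to compound 4 (0.20 log units; within the scatter) that may well stay inside the scatter. Compound 4 is estimated at 3000 nM, with a range from 900 nM to 10000 nM.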

Compound 4, half-maximal inhibitory concentration: > 30000 nM
Compound 4: a limit, no number (the forecaster's own chance of this, stated with the estimate: 5%); at least 10-fold (1.00 log units) between middle value and limit.
By their numbers in this assay, from the lowest: compounds 1 and 2 (each within the scatter of the next); then compound 3. At a limit, above all of these: compound 4.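

In this assay, within the data shown here, the group on this aromatic carbon turns out to matter strongly: phenoxy in place of trifluoromethyl gives an at least 15-fold higher number from compound 1 to compound 4 (1.19 log units; beyond the scatter), the first single-place step here that lies beyond the scatter, whereas a 1.2-fold higher number from compound 1 to compound 2 (0.06 log units; within the scatter) did not. From the compounds shown here alone, the result for compound 4 is a limit and not a number: the limit of > 30000 nM in this assay, at which 1 of the 4 values shown sits. So this change at this position can cost a great deal, and the true size of the step stays unknown beyond what the limit shows.

The swap brings in more heavy atoms, a carbon ring and an oxygen all at once, so the compounds shown cannot separate these features from one another. Going by these compounds, what a methoxy group, an amine or a carboxylic acid would give at this position remains open.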